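The compounds below may be only part of what the source reports. "The series", "measured", "known", "first", "only" and "open" are said of these compounds alone.

Going by the values given here, in a physicochemical assay for lipophilicity (on this read-out lower numbers stand for lower lipophilicity and higher numbers for higher lipophilicity), compound 2 `C[n+]1ccn(COCCCCS(C)(=O)=O)c1/C=N/O` gives -3.11, the lowest of the three numbers known so far. Among the compounds with values here, compound 1 `C[n+]1ccn(COCCCS(C)(=O)=O)c1/C=N/O` gives -2.5, and the only single-point step measured, a number 0.61 log units lower from compound 1 to compound 2 (beyond the scatter), is a modest one. Compound 3 `C[n+]1ccn(CCCC(C)(C)[N+](=O)[O-])c1/C=N/O` gives -2.18, the highest of the three. Compound 4 `C[n+]1ccn(COCCC[N+](=O)[O-])c1/C=N/O` differs from compound 2 by one change: nitro in place of (methylsulfonyl)methyl on a saturated chain carbon, three bonds along the chain from an oxygen on a saturated carbon. Within the data shown here, no measured step covers the swap of a sulfone-bearing group for a nitro group directly; compound 3 also carries a nitro but differs in more than one place, so its value only shows where a nitro-bearing chain can land. On that basis the step of a number 0.41 log units higher from compound 2 to compound 4 (beyond the scatter) is expected to be an increase, and compound 4 is estimated at -2.7, somewhere between -3.4 and -2.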

Compound 4, distribution coefficient: -2.65
For compound 4 the middle estimate is 0.05 log units below the measured one; the range from low to high includes it.
By their numbers in this assay, from the lowest: compound 2; then compounds 4 and 1 (each within the scatter of the next); then compound 3.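

In this assay, swapping (methylsulfonyl)methyl for nitro on this saturated chain carbon is a modest step (a number 0.46 log units higher from compound 2 to compound 4 (beyond the scatter)). Swapping methylsulfonyl for nitro at the same place is a step within the scatter (a number 0.15 log units lower from compound 1 to compound 4 (within the scatter)), so this read-out does not separate the nitro and methylsulfonyl compounds, while the (methylsulfonyl)methyl compound stands apart from both. No supporting measurement gives a reason for these steps.

Where an amine or a carboxylic acid would land at this place remains open. So does whether a longer chain carrying the sulfone would extend the step seen with (methylsulfonyl)methyl.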